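The compounds below may be only part of what the source reports. "The series", "measured", "known", "first", "only" and "open" are said of these compounds alone.

Measured compounds in a functional assay on PANC-1 cells (Homo sapiens) for inhibition, read by MTT assay, with a stated time of 24 h, tested at 10 uM; on this read-out lower numbers stand for less inhibition and higher numbers for more inhibition at the one concentration tested (going by the name of the read-out):
compound 1, `CC(C)=CCC1Cc2c(O)cc(=O)n(CCCO)c2CC1(C)C`, gives 0%
compound 2, `CC(C)=CCC/C(C)=C/COc1cc(=O)n(CCCO)c2c1CC(CC=C(C)C)C(C)(C)C2`, gives 18.4%
compound 3, `CC(C)=CCC1Cc2c(OCCCNC(=O)c3ccco3)cc(=O)n(CCCO)c2CC1(C)C`, gives 4.3%

Compound 3 holds the second highest of the three numbers. Its nearest neighbour is compound 1, and the step of a number 4.3 percentage points higher from compound 1 to compound 3 (within the scatter) stays within the scatter, so the two cannot be told apart. Compound 2 is furthest away: the step of a number 14.1 percentage points lower from compound 2 to compound 3 (beyond the scatter) lies beyond the scatter, though it is modest.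

Compound 4 is `COc1ccc(NC(=O)Oc2cc(=O)n(CCCO)c3c2CC(CC=C(C)C)C(C)(C)C3)cc1`. It differs from compound 3 in one place: (4-methoxyphenyl)carbamoyl in place of 3-(((furan-2-yl)carbonyl)amino)propyl on an oxygen on an aromatic ring.

For the measured compounds named here, the steps that bear on this change are those at the same oxygen. The step of a number 18.4 percentage points higher from compound 1 to compound 2 (beyond the scatter) is modest, the step of a number 4.3 percentage points higher from compound 1 to compound 3 (within the scatter) is within the scatter, and the step of a number 14.1 percentage points lower from compound 2 to compound 3 (beyond the scatter) is modest. Replacing one group on this oxygen by another has so far moved this assay only modestly, and every number stays low. Compound 4 carries a group of the same size as the one it replaces, so the expected step of a number 3.7 percentage points higher from compound 3 to compound 4 (within the scatter) is small, with no clear direction beyond the scatter. Compound 4 is therefore estimated at 8% in this assay, in a range from 0% to 28%.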

Compound 4, a percentage reported as inhibition, at one concentration (the size of the read-out at that concentration, not a potency): 0%
Beside the measured number, compound 4's estimate is 8 percentage points above it, within the range that was stated.
By their numbers in this assay, from the lowest: compounds 1, 4 and 3 (each within the scatter of the next); then compound 2.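

At the oxygen on an aromatic ring, compound 4 brings in an aromatic ring of carbon only, and in this assay the step of a number 4.3 percentage points lower from compound 3 to compound 4 (within the scatter) shows that exchanging the 3-(((furan-2-yl)carbonyl)amino)propyl group for (4-methoxyphenyl)carbamoyl, which has the same heavy-atom count, leaves the two compounds indistinguishable. The step of no change at the digits printed from compound 1 to compound 4 (within the scatter) places this carbamoyl group level with plain hydrogen on that oxygen, while the step of a number 18.4 percentage points lower from compound 2 to compound 4 (beyond the scatter) separates it from 3,7-dimethylocta-2,6-dien-1-yl, so among the four compounds only that chain stands apart from hydrogen beyond the scatter, and neither of the two groups that carry an amide or carbamoyl nitrogen does. Nothing available explains why this one chain stands apart.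

Going by these compounds, it remains open whether the number of compound 2 belongs to that particular chain, or whether a saturated decyl chain or a shorter 3-methylbut-2-en-1-yl chain on this oxygen would give a similar reading. Also open, on these data alone, is whether an amine or a carboxylic acid in place of the methoxy group of compound 4 would move the read-out at all.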